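This account rests on a few compounds, and the source may have more. Where it says the series, first, only, none or still open, it means among the compounds named here.

For the measured compounds named here, in an assay for inhibition of Polyunsaturated fatty acid 5-lipoxygenase (Homo sapiens), read by spectrophotometry, tested at 20 uM (on this read-out higher numbers stand for more inhibition at the one concentration tested (going by the name of the read-out) and lower numbers for less inhibition), compound 1 `CN(C)c1ccc(/C=C/C=C/C(=O)N2CCCCC2)cc1` gives 13.4%, the lowest of the three numbers measured so far. Compound 3 `COc1cc(/C=C/C=C/C(=O)N2CCCCC2)cc(OC)c1O` gives 32.7% and compound 2 `COc1cc(OC)c(/C=C/C=C/C(=O)N2CCCCC2)c(OC)c1` gives 77.1%, each beyond the scatter above compound 1. Compound 4 `O=C(/C=C/C=C/c1ccc(O)cc1)N1CCCCC1` has not yet been measured. It differs from compound 1 by hydroxy in place of dimethylamino on an aromatic carbon. Going by the values given here, no measured pair covers this exact change, so the size of the step is uncertain; compound 3, which also carries a hydroxy and gives 32.7%, is the only hint that a hydroxy-bearing compound may sit higher than compound 1. The step from compound 1 to compound 4 is expected to be a number 11.6 percentage points higher from compound 1 to compound 4 (beyond the scatter), upward but modest. Compound 4 is accordingly estimated at 25%, within 8% to 45%.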

Compound 4, a percentage reported as inhibition, at one concentration (the size of the read-out at that concentration, not a potency): 44.4%
Compound 4: the middle estimate sits 19.4 percentage points below what was measured; measured number inside the range.
By their numbers in this assay, from the lowest: compound 1; then compound 3; then compound 4; then compound 2.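

Replacing dimethylamino with hydroxy on this aromatic carbon, para to a large group, gives a number 31 percentage points higher from compound 1 to compound 4 (beyond the scatter) in this assay and provides the first single-place step among these compounds. It shows that the read-out depends on which of these two groups occupies the position. Nothing on hand accounts for the size of the step.

From the compounds shown here alone, whether a primary amine or a carboxylic acid at the same carbon would read closer to hydroxy or to dimethylamino remains open. So does whether the step would persist with the piperidine amide replaced.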